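Removing One Chloro from Compound 3

The compounds below may be only part of what the source reports. "The series", "measured", "known", "first", "only" and "open" are said of these compounds alone.

- compound 1 `COc1ccc(S(=O)(=O)Nc2ccc(-c3nc4cc(NS(=O)(=O)c5ccc(OC)cc5)ccc4o3)cc2)cc1`: 40000 nM
- compound 2 `COc1ccc(S(=O)(=O)Nc2ccc3oc(-c4ccc(NC(=O)c5cccc(C)c5[N+](=O)[O-])cc4)nc3c2)cc1`: 2300 nM
- compound 3 `O=C(Nc1ccc(Sc2nc3ccccc3s2)c(Cl)c1)c1cccc(Br)c1O`: 20000 nM

All three compounds were measured in a functional assay on HT-29 cells (Homo sapiens) for cytotoxicity, read by resazurin assay, with a stated time of 48 h; on this read-out higher numbers stand for an effect only at larger amounts of compound and lower numbers for an effect already at smaller amounts. In this assay compound 3 gives 20000 nM, which lies within the usual scatter of the number for compound 1, while compound 2 has a number lower by more than the scatter.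

Compound 4 `O=C(Nc1ccc(Sc2nc3ccccc3s2)cc1)c1cccc(Br)c1O` has not yet been measured. It differs from compound 3 by one change, (hydrogen in place of chloro on an aromatic carbon), with hydrogen in place of chloro on an aromatic carbon.

Within the data shown here, the only measured step is a large one, a 17-fold lower number from compound 1 to compound 2 (1.24 log units; beyond the scatter). Among the measured compounds shown here, it swaps a different group on a different core, so it says little about this change, and no measured pair covers the loss of a chloro.

With no evidence for a direction, the expected outcome in this assay is no shift beyond the scatter, no change at the digits printed from compound 3 to compound 4 (within the scatter). This expectation stays anchored on compound 3 at 20000 nM.

For compound 4 the estimated value is 20000 nM, with an expected range from 8000 nM to 50000 nM.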

Compound 4, half-maximal effective concentration: 9300 nM
Beside the measured number, compound 4's estimate is 2.2-fold (0.33 log units) above it, and the stated range covers the measured number.
By their numbers in this assay, from the lowest: compound 2; then compound 4; then compounds 3 and 1 (each within the scatter of the next).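

In this assay, among these compounds, the loss of the chloro gives the first measured reading at this position (with a 2.2-fold lower number from compound 3 to compound 4 (0.33 log units; beyond the scatter)), a modest step that the earlier compounds could not supply. It shows that on this six-membered aromatic ring of carbon only, hydrogen in place of chloro, ortho to a large group and meta to a large group, does not cost effect on these cells: the number goes down, not up. Nothing measured here accounts for the direction or the size of this shift.

Going by these compounds, whether a different group at this place, such as a fluoro, a methyl or an amine, would give a lower or a higher number remains open. Also open, on these data alone, is whether this step would keep its size with the bromo replaced.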